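The source may report more compounds than this note shows. Statements on the series, on what has been measured and on what is new or still open speak of the compounds shown alone.

Compound 2 `CCOC(=O)N1CCC(N2CCC[C@@H](NC(=O)c3cccc(F)c3)C2)CC1` and compound 1 `CCOC(=O)N1CCC(N2CCC[C@@H](NC(=O)c3ccc(C)cc3)C2)CC1` share one core and differ only in the group on the carbonyl carbon. In a functional assay on CHO cells for agonist activity at muscarinic acetylcholine receptor M5 (Rattus norvegicus) (on this read-out higher numbers stand for an effect only at larger amounts of compound and lower numbers for an effect already at smaller amounts), compound 1 reaches only the limit of > 10000 nM. Compound 2 likewise reaches only the limit of > 10000 nM in this assay. The step that the two limits leave unreadable from compound 1 to compound 2 therefore cannot be read, since (the limit of > 10000 nM in this assay, at which 2 of the 2 values shown sit). Compound 3 `CCOC(=O)N1CCC(N2CCC[C@@H](NC(=O)c3ccccc3)C2)CC1` differs from compound 2 by hydrogen in place of fluoro on an aromatic carbon. For the measured compounds named here, with both measured compounds at the limit, no sized step is available to guide this change, so compound 3 is expected to stay near that limit, a step that the limit leaves unreadable from compound 2 to compound 3. Compound 3 is estimated at 15000 nM, between 4000 nM and 60000 nM.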

Compound 3, half-maximal effective concentration: > 10000 nM
Compound 3 gave a limit, no number; the forecaster's own chance of this, stated with the estimate: 80%; the middle value lies beyond the limit too.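

For the compounds shown here, no step in size can be read among compound 1, compound 2 and compound 3, since all three share one limit: (the limit of > 10000 nM in this assay, at which 3 of the 3 values shown sit). The compounds shown leave open whether changing the group on this aromatic ring can shift the read-out in this assay at all.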